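The source may report more compounds than this note shows. Statements on the series, on what has been measured and on what is new or still open speak of the compounds shown alone.

Compound 3 `CN(c1ccc([N+](=O)[O-])cc1OC1CCCCC1)S(C)(=O)=O` gives 470 nM in an assay on SK-BR-3 cells for inhibition of Aromatase (Homo sapiens); a lower number here means a stronger inhibitor, a higher number a weaker inhibitor. Among the three compounds measured it stands second highest: compound 1 `CCC(CC)Oc1cc([N+](=O)[O-])ccc1NS(C)(=O)=O` gives 300 nM in this assay, within the scatter of compound 3, and compound 2 `CCCCCCCCCOc1cc([N+](=O)[O-])ccc1NS(C)(=O)=O` gives 910 nM, also within the scatter of compound 3. Compound 4 `COc1cc([N+](=O)[O-])ccc1N(C)S(C)(=O)=O` differs from compound 3 by methyl in place of cyclohexyl on an oxygen on an aromatic ring, that is, cyclohexyloxy to methoxy. Within the data shown here, no measured pair shows this change, and the spread between compound 1 and compound 2 stays within the scatter, so the data give little guide. A modest loss of potency is expected, as the step of a 2.6-fold higher number from compound 3 to compound 4 (0.41 log units; beyond the scatter) in this assay. Compound 4 is therefore estimated at 1200 nM, with a range from 300 nM to 5000 nM.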

Compound 4, half-maximal inhibitory concentration: > 25000 nM
Compound 4: a limit, no number; the forecaster's own chance of this, stated with the estimate: 10%; middle value at least 20-fold (1.31 log units) from the limit.
By their numbers in this assay, from the lowest: compounds 1, 3 and 2 (each within the scatter of the next, the first and the last beyond it). At a limit, above all of these: compound 4.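

In this assay, methyl in place of cyclohexyl on an oxygen on an aromatic ring gives an at least 53-fold higher number from compound 3 to compound 4 (1.72 log units; beyond the scatter), a large step. For compound 4 the reading is a limit of the assay and not a number: the limit of > 25000 nM in this assay, at which 1 of the 4 values shown sits. The earlier compounds shown here all carry a larger group on this oxygen and gave no sign that the change could cost this much.

The compounds shown leave open how much of the group this position needs, since ethyl or cyclopentyl on this oxygen lies between the two ends. They also leave open how an amine in its place would read.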